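From fluoro to chloro: notes on compound 4

This account rests on a few compounds, and the source may have more. Where it says the series, first, only, none or still open, it means among the compounds named here.

In a functional assay on A549 cells (Homo sapiens) for antiproliferative activity, read by MTT assay, with a stated time of 72 h (a lower number here means a stronger inhibitor, a higher number a weaker inhibitor), compound 1 (`COc1cc(CCc2ccc(Cl)c(Cl)c2)cc(OC)c1O`) reads 13400 nM and compound 2 (`COc1cc(CCc2ccc(F)cc2)cc(OC)c1O`) reads 4150 nM on the shared core. Compound 3 (`COc1cc(CCc2ccccc2Cl)cc(OC)c1O`) reads 2130 nM in the same test. Compound 2 lies within the scatter of compound 3, while compound 1 has a higher number than compound 2 by more than the scatter.

The step to compound 4 (`COc1cc(CCc2ccc(Cl)cc2)cc(OC)c1O`) puts chloro in place of fluoro on an aromatic carbon. Within the data shown here, no measured pair isolates this change, so the data offer no direct guide to its size. Chloro is also carried by compound 3 at 2130 nM and by compound 1 at 13400 nM and these two values do not point in one direction relative to compound 2. No shift beyond the scatter is therefore expected in this assay, with a slight rise at most. The expected change (a 1.2-fold higher number from compound 2 to compound 4 (0.06 log units; within the scatter)) is small. For compound 4 the estimated value is 4800 nM with an expected range from 2000 nM to 12000 nM in this assay.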

Compound 4, half-maximal inhibitory concentration: 22900 nM
Compound 4: the middle estimate sits 4.8-fold (0.68 log units) below what was measured, and the stated range ends below it.
By their numbers in this assay, from the lowest: compounds 3 and 2 (each within the scatter of the next); then compounds 1 and 4 (each within the scatter of the next).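

In this assay, among these compounds, chloro in place of fluoro on an aromatic carbon, para to a large group, now has a direct reading on the shared core: a 5.5-fold higher number from compound 2 to compound 4 (0.74 log units; beyond the scatter) and so beyond the scatter, which the earlier compounds could not show. Hydrogen in place of chloro on an aromatic carbon gives a 1.7-fold higher number from compound 1 to compound 4 (0.23 log units; within the scatter) and so shows no shift beyond the scatter, which means the chloro that compound 1 carries in addition to the one it shares with compound 4 adds no separate change that can be read here. No measurement at hand accounts for the gap between fluoro and chloro at this position.

The shared core is shown with only fluoro and chloro at this position, so it remains open whether bromo, methoxy or an amine there would read closer to compound 2 or to compound 4. As far as these compounds go, the reading with hydrogen alone at this position, which would show whether fluoro or chloro is the group that departs from it, also remains open.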